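A few compounds are considered here, and "the series" means these few. Any claim that something is new, unique, unknown or untested is made for them only; others in the source may bear on it.

Compound 3 `COc1ccc(/C=C/C(=O)Nc2cc(C(=O)c3cc(OC)c(OC)c(OC)c3)ccc2OC)cc1` gives 10900 nM in a functional assay on COLO 205 cells (Homo sapiens) for cytotoxicity, read by MTT assay, with a stated time of 72 h (on this read-out lower numbers stand for stronger inhibition and higher numbers for weaker inhibition), the highest number among the three measured compounds. Among the measured compounds shown here, its nearest neighbour is compound 2 `COc1ccc(C(=O)c2cc(OC)c(OC)c(OC)c2)cc1NC(=O)/C=C/c1ccc(OC)c(OC)c1`, which gives 8200 nM; the one step recorded between them, a 1.3-fold higher number from compound 2 to compound 3 (0.12 log units; within the scatter), came from hydrogen in place of methoxy on an aromatic carbon and stayed within the scatter. Compound 1 `COc1cccc(/C=C/C(=O)Nc2cc(OC)c(OC)c(OC)c2)c1` gives 4200 nM, a number that lies beyond the scatter from compound 3; the two structures differ in more than one place, so only their two values are shown, with no single step between them.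

Compound 4 `C#CCOc1cccc(/C=C/C(=O)Nc2cc(C(=O)c3cc(OC)c(OC)c(OC)c3)ccc2OC)c1` is the next compound in the series. The change from compound 3 is 3-(propargyloxy)phenyl in place of 4-methoxyphenyl on a double-bonded chain carbon bound to a double-bonded chain carbon. For the measured compounds named here, no measured step changes this part of the molecule, so the expectation rests loosely on two points: the only measured step, from compound 2 to compound 3, was within the scatter, and the values of compound 1 and compound 3 show that a methoxy placed differently on this ring went with a lower number. Compound 4 is therefore expected to show a modest step, a 1.4-fold lower number from compound 3 to compound 4 (0.13 log units; within the scatter), towards a lower number, with wide uncertainty. The estimate for compound 4 is 8000 nM, with a range from 3000 nM to 25000 nM.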

Compound 4, half-maximal inhibitory concentration: 13400 nM
The estimate for compound 4 lay 1.7-fold (0.22 log units) below the measured number, within the range that was stated.
By their numbers in this assay, from the lowest: compounds 1, 2, 3 and 4 (each within the scatter of the next, the first and the last beyond it).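

In this assay, the position on a double-bonded chain carbon bound to a double-bonded chain carbon now has a measured step: 3-(propargyloxy)phenyl in place of 4-methoxyphenyl gives a 1.2-fold higher number from compound 3 to compound 4 (0.09 log units; within the scatter), and the same group in place of 3,4-dimethoxyphenyl gives a 1.6-fold higher number from compound 2 to compound 4 (0.21 log units; within the scatter). Among the compounds shown here, earlier, the only step at this place was the removal of a single methoxy group, whereas these steps bring in a group with more heavy atoms and a triple bond, and neither step leaves the scatter, so the three aryl groups on the shared core cannot be ranked in this read-out. The data offer no information that would explain this outcome.

On these data alone, the step from compound 3 to compound 4 changes the place of the oxygen substituent on the ring and exchanges methyl for propargyl together, so the separate contribution of each change remains open. Also open, as far as these compounds go, is whether the read-out would move beyond the scatter with an amine, a carboxylic acid or a longer chain in place of the propargyloxy group.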